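From methoxy to benzamido: an expected change in tolerance

A few compounds are considered here, and "the series" means these few. Any claim that something is new, unique, unknown or untested is made for them only; others in the source may bear on it.

In a functional assay on CCRF-CEM cells (Homo sapiens) (a higher number here means that more compound is tolerated, a lower number that less compound is tolerated), compound 3 `COC(=O)NC1=CS(=O)(=O)O[C@@]12[C@@H](CO[Si](C)(C)C(C)(C)C)O[C@@H](n1cc(C)c(=O)n(C)c1=O)[C@@H]2O[Si](C)(C)C(C)(C)C` gives 30700 nM, the highest of the three measured values. Compound 2 `Cc1cn([C@@H]2O[C@H](CO[Si](C)(C)C(C)(C)C)[C@@]3(OS(=O)(=O)C=C3NCC(=O)C(N)=O)[C@H]2O[Si](C)(C)C(C)(C)C)c(=O)n(C)c1=O` gives 9960 nM, and compound 1 `CCOC(=O)CNC(=O)NC1=CS(=O)(=O)O[C@@]12[C@@H](CO[Si](C)(C)C(C)(C)C)O[C@@H](n1cc(C)c(=O)n(C)c1=O)[C@@H]2O[Si](C)(C)C(C)(C)C` gives 5020 nM, both separated from compound 3 by steps beyond the scatter. Compound 4 `Cc1cn([C@@H]2O[C@H](CO[Si](C)(C)C(C)(C)C)[C@@]3(OS(=O)(=O)C=C3NC(=O)NC(=O)c3ccccc3)[C@H]2O[Si](C)(C)C(C)(C)C)c(=O)n(C)c1=O` differs from compound 3 by benzamido in place of methoxy on a carbonyl carbon. Among the compounds with values here, two measured steps bear on this change: a 6.1-fold higher number from compound 1 to compound 3 (0.79 log units; beyond the scatter) and a 3.1-fold higher number from compound 2 to compound 3 (0.49 log units; beyond the scatter). In both, the small methoxy-bearing compound 3 is tolerated better than a larger-substituted analogue, so enlarging the group again is expected to lower the number modestly. Compound 4 is therefore expected to give about 9000 nM, within a range of 3000 nM to 27000 nM. The expected step is a 3.4-fold lower number from compound 3 to compound 4 (0.53 log units; beyond the scatter).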

Compound 4, half-maximal cytotoxic concentration: 2290 nM
Estimate against measurement, compound 4: 3.9-fold (0.59 log units) above, and the stated range ends above it.
By their numbers in this assay, from the lowest: compound 4; then compounds 1 and 2 (each within the scatter of the next); then compound 3.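

In this assay benzamido in place of methoxy on this carbonyl carbon gives a 13-fold lower number from compound 3 to compound 4 (1.13 log units; beyond the scatter) and so the largest step among these compounds, while the other two comparisons give a 4.3-fold lower number from compound 2 to compound 4 (0.64 log units; beyond the scatter) and a 2.2-fold lower number from compound 1 to compound 4 (0.34 log units; beyond the scatter) as well. Compound 4 is thus the least tolerated of the four, and the only one with a six-membered aromatic ring in this group. Nothing shown gives a reason for this result. On these data alone, it stays open whether the step follows the aromatic ring or the amide hydrogen of benzamido, a question that a cyclohexanecarbonylamino or a phenoxy group at this carbonyl carbon could help to separate.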